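Three Spiro Analogues at the Assay Limit and a Nitro Variant

This account rests on a few compounds, and the source may have more. Where it says the series, first, only, none or still open, it means among the compounds named here.

Compound 1 `CCOc1ccccc1-n1nncc1CN1C(=O)C2(C(C#N)=C(N)Oc3c2c2nc4ccccc4nc2c2ccccc32)c2ccccc21`: in a functional assay on HCT-116 cells (Homo sapiens) for antiproliferative activity, read by MTT assay, with a stated time of 48 h (on this read-out higher numbers stand for weaker inhibition and lower numbers for stronger inhibition), compound 1 gives > 50000 nM, a limit of the assay.
Compound 2 `Cc1ccc(Cl)cc1-n1nncc1CN1C(=O)C2(C(C#N)=C(N)Oc3c2c2nc4ccccc4nc2c2ccccc32)c2ccccc21`: in this assay compound 2 gives > 50000 nM, a limit of the assay.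
Compound 3 `N#CC1=C(N)Oc2c(N)cc3nc4ccccc4nc3c2C12C(=O)N(Cc1cnnn1-c1ccccc1Cl)c1ccccc12`: in this assay compound 3 gives > 50000 nM, a limit of the assay.

Compound 3 therefore stands where every measured compound in this set stands, at the limit described by the limit of > 50000 nM in this assay, at which 3 of the 3 values shown sit, so no ranking among compounds 1, 2 and 3 can be drawn. For the measured compounds named here, the one measured step, a step that the two limits leave unreadable from compound 1 to compound 2, runs between two limits and its size cannot be read. Compound 4 `N#CC1=C(N)Oc2c(N)cc3nc4ccccc4nc3c2C12C(=O)N(Cc1cnnn1-c1ccc(Cl)cc1[N+](=O)[O-])c1ccccc12` differs from compound 3 in one place: 4-chloro-2-nitrophenyl in place of 2-chlorophenyl on an aromatic nitrogen. Going by the values given here, the only measured change on this aromatic nitrogen gave no readable size, so nothing in the data points to a step beyond the scatter in either direction. Compound 4 is therefore expected to sit at or near the same limit, with a step that the limit leaves unreadable from compound 3 to compound 4 as the estimated step, and its estimated value in this assay is 60000 nM, within a range from 15000 nM to 250000 nM.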

Compound 4, half-maximal inhibitory concentration: 28700 nM
Estimate against measurement, compound 4: 2.1-fold (0.32 log units) above, within the range that was stated.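

For the compounds shown here, compound 4 is the first compound in this set whose result in this assay is a reading rather than a limit, so a group on this aromatic nitrogen can go with a measurable number on the shared core. The other three compounds give no such number: the limit of > 50000 nM in this assay, at which 3 of the 4 values shown sit.

The replacement of 2-chlorophenyl by 4-chloro-2-nitrophenyl gives an at least 1.7-fold lower number from compound 3 to compound 4 (0.24 log units; that floor lies within the scatter). Only a floor on the size of this step can be read, so it does not establish a gain beyond the scatter.

The compounds shown leave open whether the nitro group or the changed place of the chlorine goes with this reading, as the two differ together between compound 3 and compound 4. Also open, on these data alone, is how an amine or a carboxylic acid in place of the nitro group would read in this assay.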